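Chlorophenyl Amide Series: Growth Inhibition Working Notes

The source may hold more compounds than are shown below. What is called first, only, known or untested is meant among the compounds shown, and "the series" means these compounds.

Measured in a functional assay on HO8910 cells (Homo sapiens) for inhibition, read by MTT assay, with a stated time of 24 h, tested at 0.1 ug/mL; on this read-out lower numbers stand for less inhibition of growth and higher numbers for more inhibition of growth at the one concentration tested:
Compound 1, `CC(=O)SCCC(CCCCC(=O)Nc1cccc(Cl)c1)SC(C)=O`, gives 0.27%.
Compound 2, `CC(=O)SCCC(CCCCC(=O)Nc1ccc(Cl)cc1)SC(C)=O`, gives 1.81%.
Compound 3, `O=C(CCCCC(CCSC(=O)c1ccccc1)SC(=O)c1ccccc1)Nc1cccc(Cl)c1`, gives 9.02%.

Compounds 1 and 2 differ only by 4-chlorophenyl in place of 3-chlorophenyl on an amide-type nitrogen, and this change gave a number 1.5 percentage points higher from compound 1 to compound 2 (within the scatter). How the core of compound 1 and the core of compound 3 differ is not broken down here; their values in this assay lie within the scatter of each other, as does compound 3 against compound 2.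

Compound 4, `O=C(CCCCC(CCSC(=O)c1ccccc1)SC(=O)c1ccccc1)Nc1ccc(Cl)cc1`, has not been measured. It differs from compound 3 by 4-chlorophenyl in place of 3-chlorophenyl on an amide-type nitrogen, the same change as between compounds 1 and 2, at the same place. Since that change moved the value from compound 1 to compound 2 by only a number 1.5 percentage points higher from compound 1 to compound 2 (within the scatter), a comparably small step is expected, a number 1.5 percentage points higher from compound 3 to compound 4 (within the scatter), with compound 4 estimated at 10.5%. The expected range for compound 4 runs from 0% to 20%.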

Compound 4, percent growth inhibition at one concentration: 3.68%
For compound 4 the middle estimate is 6.8 percentage points above the measured one; low and high end bracket the measured number.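

In this assay, 4-chlorophenyl in place of 3-chlorophenyl on an amide-type nitrogen gives a number 5.3 percentage points lower from compound 3 to compound 4 (within the scatter). Set side by side, the two steps do not separate the cores: the same change on two cores in this assay, a number 1.5 percentage points higher (within the scatter) from compound 1 to compound 2 and a number 5.3 percentage points lower (within the scatter) from compound 3 to compound 4, 6.9 percentage points apart, within the scatter of two such steps. Neither step lies beyond the scatter, so the change shows no measurable effect on either core, and these data cannot show whether a real effect would carry from one core to the other.

As far as these compounds go, it remains open whether any replacement on this amide-type nitrogen, such as a plain phenyl or a pyridine in place of the chlorophenyl, would give a step beyond the scatter. Also open, from the compounds shown here alone, is how a free thiol in place of the thioester groups would read.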